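Cyclic diamine replaces the methoxyethylamine on the sulfonyl chain

The source may hold more compounds than are shown below. What is called first, only, known or untested is meant among the compounds shown, and "the series" means these compounds.

Compound 1 `COCCNCCCS(=O)(=O)c1ccc2nc(NC(=O)NC(=O)c3ccccc3Cl)sc2c1` gives 8.6 nM in an assay on HEK293 cells for displacement of a labelled ligand from growth hormone secretagogue receptor type 1 (Homo sapiens), with a stated time of 60 min (a higher number here means a weaker inhibitor, a lower number a stronger inhibitor), the highest of the two numbers measured; compound 2 `CN1CCN(CCCS(=O)(=O)c2ccc3nc(NC(=O)NC(=O)c4cc(-n5cccc5)ccc4Cl)sc3c2)CC1` gives 0.15 nM in this assay, a gap beyond the usual scatter, though the two differ in more than one place. Compound 3 `CN1CCCN(CCCS(=O)(=O)c2ccc3nc(NC(=O)NC(=O)c4ccccc4Cl)sc3c2)CC1` differs from compound 1 by 4-methyl-1,4-diazepan-1-yl in place of (2-methoxyethyl)amino on a saturated chain carbon, three bonds along the chain from a sulfonyl sulfur. For the measured compounds named here, with no single-change step measured, the writer expects a lowering a 2.9-fold lower number from compound 1 to compound 3 (0.46 log units; beyond the scatter) for compound 3, modest but beyond the scatter, resting on the low value of compound 2 at 0.15 nM. Compound 3 is estimated at 3 nM, between 0.8 nM and 12 nM.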

Compound 3, half-maximal inhibitory concentration: 4.2 nM
The estimate for compound 3 lay 1.4-fold (0.15 log units) below the measured number; measured number inside the range.
By their numbers in this assay, from the lowest: compound 2; then compound 3; then compound 1.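

On a saturated chain carbon, three bonds along the chain from a sulfonyl sulfur, 4-methyl-1,4-diazepan-1-yl in place of (2-methoxyethyl)amino gives a 2.0-fold lower number from compound 1 to compound 3 (0.31 log units; beyond the scatter) in this assay. This single-change step shows that the place accepts a seven-membered non-aromatic ring and the loss of the hydrogen-bond donor without a rise in the number. Nothing at hand explains the step. Still open, going by these compounds, is whether a morpholine or a shorter chain would serve here, and whether the step would carry over to the other substitution of compound 2.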